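The source may hold more compounds than are shown below. What is called first, only, known or untested is meant among the compounds shown, and "the series" means these compounds.

Three related compounds have been tested so far. Compound 1 `COc1cc(/C=C/C(=O)C(=Cc2ccc(O)c(O)c2)C(=O)/C=C/c2ccc(O)c(OC)c2)ccc1O` gives 2200 nM in a functional assay, read by spectrophotometry, with a stated time of 5 min; a lower number here means a stronger inhibitor, a higher number a weaker inhibitor. Compound 2 `CCOc1ccc(C=C(C(=O)/C=C/c2ccc(O)c(OC)c2)C(=O)/C=C/c2ccc(O)c(OC)c2)cc1OCC` gives 10000 nM in this assay. Compound 3 `CCOc1cc(/C=C/C(=O)C(=Cc2ccc(O)c(O)c2)C(=O)/C=C/c2ccc(O)c(OCC)c2)ccc1O` gives 3630 nM in this assay, which sits within the usual scatter of compound 1 and beyond it from compound 2. Compound 4 `CCOc1cc(/C=C/C(=O)C(=Cc2ccc(OCC)c(OCC)c2)C(=O)/C=C/c2ccc(O)c(OCC)c2)ccc1O` has not yet been measured.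

Compound 2 differs from compound 1 by one change, (3,4-diethoxyphenyl in place of 3,4-dihydroxyphenyl on a double-bonded chain carbon bound to a double-bonded chain carbon), and this change gave a 4.5-fold higher number from compound 1 to compound 2 (0.66 log units; beyond the scatter). Compound 4 differs from compound 3 by the same change, (3,4-diethoxyphenyl in place of 3,4-dihydroxyphenyl on a double-bonded chain carbon bound to a double-bonded chain carbon), at the same place. How the core of compound 3 differs from the core of compound 1 is not broken down here.

Within the data shown here, because the single earlier example of this change gave a 4.5-fold higher number from compound 1 to compound 2 (0.66 log units; beyond the scatter), the step from compound 3 to compound 4 is expected to be of similar size, estimated as a 3.9-fold higher number from compound 3 to compound 4 (0.59 log units; beyond the scatter). This expectation rests on one prior pair only, so it is uncertain. Compound 4 is therefore estimated at 14000 nM, most likely between 6000 nM and 35000 nM.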

Compound 4, half-maximal inhibitory concentration: 20200 nM
Beside the measured number, compound 4's estimate is 1.4-fold (0.16 log units) below it, and the stated range covers the measured number.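

Replacing 3,4-dihydroxyphenyl with 3,4-diethoxyphenyl on a double-bonded chain carbon again gives a weaker inhibitor in this assay, with a 5.6-fold higher number from compound 3 to compound 4 (0.75 log units; beyond the scatter). Set beside the earlier example, the change carries over from one core to the other at much the same size: the same change on two cores in this assay, a 4.5-fold higher number (0.66 log units; beyond the scatter) from compound 1 to compound 2 and a 5.6-fold higher number (0.75 log units; beyond the scatter) from compound 3 to compound 4, 1.2-fold (0.09 log units) apart, within the scatter of two such steps. Among these compounds, this covers only two pairs, so it is no general rule for the series, and it does not explain the loss: the swap removes the hydrogen-bond donors and enlarges the group at once, and these two differences cannot be told apart here.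

The compounds shown include no 3,4-dimethoxyphenyl group, no ring with one hydroxyl and one ethoxy, and no ring carrying an amine or a carboxylic acid, so it remains open how the number would respond to smaller or different steps at this place. Going by these compounds, it also remains open whether the step keeps its size on cores other than these two.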